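Compound 4 set against the piperidinyl compounds 1 to 3

The source may hold more compounds than are shown below. What is called first, only, known or untested is meant among the compounds shown, and "the series" means these compounds.

Measured so far:
compound 1 `CC(C(=O)NCc1ccc(C(F)(F)F)cc1N1CCC(C(F)(F)F)CC1)c1ccc(NS(C)(=O)=O)c(F)c1`: 0.4 nM
compound 2 `CC(C(=O)NCc1ccc(C(F)(F)F)cc1N1CCC(c2ccc(F)cc2)CC1)c1ccc(NS(C)(=O)=O)c(F)c1`: 0.9 nM
compound 3 `CC(C(=O)NCc1ccc(C(F)(F)F)cc1N1CCC(Cc2ccccc2)CC1)c1ccc(NS(C)(=O)=O)c(F)c1`: 1.4 nM

In an assay on CHO cells for antagonist activity at transient receptor potential cation channel subfamily V member 1 (Homo sapiens), read by FLIPR (a lower number here means a stronger inhibitor, a higher number a weaker inhibitor), compound 1 gives the lowest of the three numbers. The step to its nearest neighbour is a 2.3-fold higher number from compound 1 to compound 2 (0.35 log units; beyond the scatter) and to the furthest a 3.5-fold higher number from compound 1 to compound 3 (0.54 log units; beyond the scatter), both beyond the scatter. Between compounds 2 and 3 the step is a 1.6-fold higher number from compound 2 to compound 3 (0.19 log units; within the scatter), within the scatter, so no order between those two is claimed.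

Compound 4 `CC(C(=O)NCc1ccc(C(F)(F)F)cc1SCCCO)c1ccc(NS(C)(=O)=O)c(F)c1` is the unmeasured member. Against compound 1 the change is (3-hydroxypropyl)sulfanyl in place of 4-(trifluoromethyl)piperidin-1-yl on an aromatic carbon. The measured steps that come closest are those from compound 1 to compounds 2 and 3, in which only the group on the saturated ring carbon was exchanged while the six-membered ring itself stayed; each of them raised the number modestly. Among the measured compounds shown here, no measured step removes that ring or introduces an acyclic chain with a hydrogen-bond donor, so the bearing of those steps on compound 4 is indirect. Given that every departure from the trifluoromethyl-bearing ring of compound 1 raised the number, a larger rise is expected for compound 4 in this assay, around a 13-fold higher number from compound 1 to compound 4 (1.10 log units; beyond the scatter). The estimate for compound 4 is 5 nM, with a range from 1 nM to 30 nM.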

Compound 4, inhibition constant: "not active" (no number reported)
Nothing numeric was reported for compound 4; no gap can be computed for the estimate.
By their numbers in this assay, from the lowest: compound 1; then compounds 2 and 3 (each within the scatter of the next).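

In this assay, among the compounds shown here, compound 4 is reported only as "not active", without a number, so no step from compound 1 to compound 4 can be read. The compounds shown leave open whether the result follows the loss of 4-(trifluoromethyl)piperidin-1-yl or the entry of (3-hydroxypropyl)sulfanyl. No measured evidence bears on this result.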